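The source may hold more compounds than are shown below. What is called first, only, known or untested is meant among the compounds shown, and "the series" means these compounds.

Among the compounds with values here, compound 2, `N#C[Se]c1ccc(NC(=O)Oc2ccc(F)cc2)cc1`, gives 33300 nM in a functional assay on MCF7 cells (Homo sapiens) for cytotoxicity, read by MTT assay, with a stated time of 72 h (a lower number here means a stronger inhibitor of growth, a higher number a weaker inhibitor of growth), and so holds the lowest of the two numbers recorded, though its only neighbour, compound 1, `COc1ccc(OC(=O)Nc2ccc([Se]C#N)cc2)cc1`, gives 48200 nM in this assay, and the one measured step, a 1.4-fold lower number from compound 1 to compound 2 (0.16 log units; within the scatter), does not rise above the scatter. Compound 3, `Cc1ccc(OC(=O)Nc2ccc([Se]C#N)cc2)cc1`, has not been measured; it is related to compound 2 by methyl in place of fluoro on an aromatic carbon. Within the data shown here, the single step that bears on this exchange is the one from compound 1 to compound 2, which swapped one small group at the same aromatic carbon and moved the number only within the scatter; on that basis no step beyond the scatter is expected in this assay for the present change, in either direction. Compound 3 is therefore estimated at 36000 nM, within a range from 15000 nM to 85000 nM. The step this estimate implies is a 1.1-fold higher number from compound 2 to compound 3 (0.03 log units; within the scatter).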

Compound 3, concentration for total growth inhibition: 39900 nM
For compound 3 the middle estimate is 1.1-fold (0.04 log units) below the measured one, within the range that was stated.
By their numbers in this assay, from the lowest: compounds 2, 3 and 1 (each within the scatter of the next).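

In this assay, methyl in place of fluoro on an aromatic carbon gives a 1.2-fold higher number from compound 2 to compound 3 (0.08 log units; within the scatter), and methyl in place of methoxy gives a 1.2-fold lower number from compound 1 to compound 3 (0.08 log units; within the scatter). Where the earlier compounds offered a single exchange, fluoro, methyl and methoxy can now be compared in pairs at this place, para to a large group, and no pair differs beyond the scatter, so none of the three can be ranked above another. Nothing available accounts for this lack of separation.

The compounds shown leave open whether an amine, a carboxylic acid or a longer chain at this place would move the number beyond the scatter. They also leave open whether changes elsewhere in the shared core would do so.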